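This account rests on a few compounds, and the source may have more. Where it says the series, first, only, none or still open, it means among the compounds named here.

Measured in an ADME assay on C8166 cells (Homo sapiens) for cytotoxicity, read by MTT assay; a higher number here means that more compound is tolerated, a lower number that less compound is tolerated:
- compound 1 `Cc1ccc(-n2cc(C(=O)O)c(=O)c3c(O)c(Cc4cccc(Cl)c4F)ccc32)cc1C`: 316000 nM
- compound 2 `O=C(O)c1cn(-c2ccc(Br)cc2)c2ccc(Cc3cccc(Cl)c3F)c(O)c2c1=O`: 85000 nM
- compound 3 `O=C(O)c1cn(Cc2ccccc2)c2ccc(Cc3cccc(Cl)c3F)c(O)c2c1=O`: 20300 nM

Compound 3 has the lowest number of the three. Compound 4 `O=C(O)c1cn(Cc2ccc(F)c(F)c2)c2ccc(Cc3cccc(Cl)c3F)c(O)c2c1=O` differs from it by 3,4-difluorophenyl in place of phenyl on a saturated chain carbon bound to an aromatic nitrogen, with 3,4-difluorophenyl in place of phenyl on a saturated chain carbon bound to an aromatic nitrogen.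

For the measured compounds named here, no measured step tests this exact change. Introducing benzyl gave larger moves, a 4.2-fold lower number from compound 2 to compound 3 (0.62 log units; beyond the scatter) and a 16-fold lower number from compound 1 to compound 3 (1.19 log units; beyond the scatter). The closest comparison exchanges ring substituents and gave a 3.7-fold lower number from compound 1 to compound 2 (0.57 log units; beyond the scatter), so a move of that size cannot be excluded.

The expected change in this assay is small and not beyond the scatter, a 1.1-fold higher number from compound 3 to compound 4 (0.03 log units; within the scatter). The estimated value for compound 4 is 22000 nM, with an expected range of 8000 nM to 60000 nM.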

Compound 4, half-maximal cytotoxic concentration: 71400 nM
Compound 4: middle estimate off by 3.2-fold (0.51 log units), on the low side, outside the stated range (above it).
By their numbers in this assay, from the lowest: compound 3; then compounds 4 and 2 (each within the scatter of the next); then compound 1.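

In this assay, substitution on the benzyl ring moves the number: the change gives a 3.5-fold higher number from compound 3 to compound 4 (0.55 log units; beyond the scatter) and so lies beyond the scatter. 3,4-Difluorobenzyl and 4-bromophenyl on the aromatic nitrogen are not separated, with a 1.2-fold lower number from compound 2 to compound 4 (0.08 log units; within the scatter) within the scatter, while 3,4-dimethylphenyl stays apart, with a 4.4-fold lower number from compound 1 to compound 4 (0.65 log units; beyond the scatter) beyond it. Nothing available explains this step.

Open, from the compounds shown here alone, is whether one fluorine alone, at either ring position, gives the same step. Also open, going by these compounds, is how a longer chain such as phenethyl or a methoxy group on the benzyl ring would behave.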